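The source may hold more compounds than are shown below. What is called first, only, known or untested is meant among the compounds shown, and "the series" means these compounds.

Of the compounds shown here, three sharing one core have been tested in an assay on CHO cells for displacement of a labelled ligand from adenosine receptor A1 (Homo sapiens), read by scintillation counting, tested at 10 uM; a higher number here means more inhibition at the concentration tested (going by the name of the read-out), a lower number less inhibition. Compound 1 `CC(C)(C)Cc1csc(N)c1C(=O)c1ccc(Cl)cc1` gives 1%. Compound 2 `CC(C)(C)Cc1c(-c2ccncc2)sc(N)c1C(=O)c1ccc(Cl)cc1`, which carries a pyridin-4-yl group, gives 1% in this assay. Compound 3 `CC(C)(C)Cc1c(-c2ccccn2)sc(N)c1C(=O)c1ccc(Cl)cc1`, which carries a pyridin-2-yl group instead, gives 1% in this assay. Compound 3 therefore stands level with compounds 1 and 2 at the digits shown: the step of no change at the digits printed from compound 1 to compound 3 (within the scatter) and the step of no change at the digits printed from compound 2 to compound 3 (within the scatter) both lie within the scatter, as does the step of no change at the digits printed from compound 1 to compound 2 (within the scatter).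

Compound 4 `CC(C)(C)Cc1c(-c2ccc(F)cc2)sc(N)c1C(=O)c1ccc(Cl)cc1` has not yet been measured. It differs from compound 3 in one place: 4-fluorophenyl in place of pyridin-2-yl on an aromatic carbon. The measured steps that bear on this are those in which a six-membered aromatic ring was placed at the same aromatic carbon or exchanged for another, and none of them moved the read-out beyond the scatter: hydrogen to pyridin-4-yl, hydrogen to pyridin-2-yl, and pyridin-4-yl to pyridin-2-yl all gave no change. A fourth ring at this carbon, 4-fluorophenyl, is therefore expected to leave the read-out where it is. The step of a number 1 percentage points higher from compound 3 to compound 4 (within the scatter) is expected to stay within the scatter. For compound 4 the estimate in this assay is 2%, with a range from -8% to 12%.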

Compound 4, a percentage reported as inhibition, at one concentration (the size of the read-out at that concentration, not a potency): 1%
Estimate against measurement, compound 4: 1 percentage points above; low and high end bracket the measured number.
By their numbers in this assay, from the lowest: compounds 1, 2, 3 and 4 (each within the scatter of the next).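

Among these compounds, compound 4 puts a ring of carbon only, bearing fluorine, at the ring carbon next to the ring sulfur, where the earlier compounds carried hydrogen or a ring with one nitrogen. In this assay, exchanging the pyridin-2-yl group for 4-fluorophenyl leaves the reading flat (no change at the digits printed from compound 3 to compound 4 (within the scatter)), and the comparisons with pyridin-4-yl (no change at the digits printed from compound 2 to compound 4 (within the scatter)) and with hydrogen (no change at the digits printed from compound 1 to compound 4 (within the scatter)) read the same way. Thus neither the ring nitrogen, with its hydrogen-bond acceptor, nor the fluorine makes a readable difference here, although no data on hand offer a reason for this flat result.

All four compounds share the same very low reading, so a change that weakened displacement would hardly show, and the series cannot tell whether this position matters for the receptor at all. Going by these compounds, it remains open whether a different kind of group on this carbon, such as an amine or a carboxylic acid, or a longer chain in place of the neopentyl group, would lift the inhibition clear of the scatter.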